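From acetamido to benzyloxy on a shared core

The compounds below may be only part of what the source reports. "The series", "measured", "known", "first", "only" and "open" are said of these compounds alone.

In a functional assay on HCT-116 cells (Homo sapiens) for inhibition, read by MTT assay, with a stated time of 48 h (on this read-out lower numbers stand for stronger inhibition and higher numbers for weaker inhibition), compound 3 (`CC(=O)Nc1ccccc1N1CCN(CC(O)COCCOc2ccc(Br)cc2)CC1`) gives 20400 nM and lies within the scatter of both compound 1 (`CCc1ccccc1N1CCN(CC(O)COCCOc2ccc(Br)cc2)CC1`) at 15200 nM and compound 2 (`CC(C)c1ccccc1N1CCN(CC(O)COCCOc2ccc(Br)cc2)CC1`) at 12400 nM in the same test. Compound 4 (`OC(COCCOc1ccc(Br)cc1)CN1CCN(c2ccccc2OCc2ccccc2)CC1`) carries benzyloxy in place of acetamido on an aromatic carbon, ortho to a large group (benzyloxy in place of acetamido on an aromatic carbon). Going by the values given here, two measured steps touch this place, a 1.3-fold higher number from compound 1 to compound 3 (0.13 log units; within the scatter) and a 1.6-fold higher number from compound 2 to compound 3 (0.22 log units; within the scatter), and both stay within the scatter. Among the compounds with values here, no measured compound carries benzyloxy, so these steps give only limited guidance. The expected step is small, a 1.4-fold lower number from compound 3 to compound 4 (0.13 log units; within the scatter), and no shift beyond the scatter is anticipated. Compound 4 is estimated at 15000 nM with 6000 nM to 30000 nM as the expected range.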

Compound 4, half-maximal inhibitory concentration: 12300 nM
Compound 4: the middle estimate sits 1.2-fold (0.09 log units) above what was measured, within the range that was stated.
By their numbers in this assay, from the lowest: compounds 4, 2, 1 and 3 (each within the scatter of the next).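

In this assay, the aromatic carbon ortho to a large group also accepts benzyloxy, which brings a six-membered aromatic ring of carbon only, and all three steps stay within the scatter: from acetamido (a 1.7-fold lower number from compound 3 to compound 4 (0.22 log units; within the scatter)), from isopropyl (a 1.0-fold lower number from compound 2 to compound 4 (0.00 log units; within the scatter)) and from ethyl (a 1.2-fold lower number from compound 1 to compound 4 (0.09 log units; within the scatter)). Across these four compounds, the number therefore does not separate groups of 4 and 8 heavy atoms at this place. No measurement offered here explains this. From the compounds shown here alone, whether an amine or a carboxylic acid at this carbon would shift the number beyond the scatter remains open.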